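Reversing an Amide Within a Shared Core

The source may hold more compounds than are shown below. What is called first, only, known or untested is meant among the compounds shown, and "the series" means these compounds.

Compound 1 `O=C(NCCO)c1cccc(Nc2ncc(F)c(Nc3ccc(F)cc3)n2)c1`, compound 2 `COc1ccc(N2CCN(C)CC2)cc1Nc1ncc(F)c(Nc2ccc(F)cc2)n1` and compound 3 `COc1ccc(NC(=O)c2cccc(Nc3ncc(F)c(Nc4ccc(F)cc4)n3)c2)cc1` share one core and differ only in the group attached to it. In a functional assay on KBVIN cells (Homo sapiens) for antiproliferative activity, read by sulforhodamine B assay, with a stated time of 3 days (a higher number here means a weaker inhibitor of growth, a lower number a stronger inhibitor of growth), compound 1 gives 21400 nM, the highest of the three numbers. Compound 3 gives 15700 nM, so that a 1.4-fold lower number from compound 1 to compound 3 (0.13 log units; within the scatter). Among the measured compounds shown here, compound 2 gives 910 nM, a far lower number, but it differs from compound 1 in more than one place, so it offers no single step. Compound 4 `O=C(Nc1cccc(Nc2ncc(F)c(Nc3ccc(F)cc3)n2)c1)c1ccccc1` has not been measured; it carries benzamido in place of (2-hydroxyethyl)carbamoyl on an aromatic carbon. For the measured compounds named here, the only measured step that bears on this change is a 1.4-fold lower number from compound 1 to compound 3 (0.13 log units; within the scatter), which also brought an aromatic ring to the amide and left the number essentially unchanged. For compound 4 the expected step is a 1.8-fold lower number from compound 1 to compound 4 (0.25 log units; within the scatter). The estimate for compound 4 is therefore 12000 nM, between 4000 nM and 40000 nM.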

Compound 4, concentration for 50% growth inhibition: > 10000 nM
Compound 4: no number, only a limit (the forecaster's own chance of this, stated with the estimate: 10%); the middle value is on the limit's open side.
By their numbers in this assay, from the lowest: compound 2; then compounds 3 and 1 (each within the scatter of the next).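

In this assay compound 4 gives > 10000 nM, which is a limit and not a number. The steps to it from compound 1 and compound 3 cannot be read. The compounds shown leave open where compound 4 actually stands relative to those two.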